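Changing the aryl group on a fused core

The compounds below may be only part of what the source reports. "The series", "measured", "known", "first", "only" and "open" are said of these compounds alone.

Compound 1 `CS(=O)(=O)c1ccc(Cc2nnc3n2N=C(c2ccc(-c4ccccc4)cc2)CS3)cc1` gives 74.8% in a functional assay on HT-29 cells (Homo sapiens) for cytotoxicity, read by MTT assay, with a stated time of 48 h, tested at 100 uM; a lower number here means a weaker effect, a higher number a stronger effect of the compound at the concentration tested.
Compound 2 `CS(=O)(=O)c1ccc(Cc2nnc3n2N=C(c2cc(Cl)sc2S(N)(=O)=O)CS3)cc1` gives 35.2% in this assay.
Compound 3 `Cc1ccc(C2=Nn3c(Cc4ccc(S(C)(=O)=O)cc4)nnc3SC2)cc1` gives 38.5% in this assay.

Among these three numbers, compound 2 stands lowest; its nearest neighbour is compound 3, with a step of a number 3.3 percentage points higher from compound 2 to compound 3 (within the scatter), while compound 1 lies far above it. The unmeasured compound 4 `CS(=O)(=O)c1ccc(Cc2nnc3n2N=C(c2ccc(O)c(C(N)=O)c2)CS3)cc1` differs from compound 2 only in the aryl group attached to the core: 3-carbamoyl-4-hydroxyphenyl in place of 5-chloro-2-sulfamoylthiophen-3-yl on a carbon with a double bond to nitrogen. Among the compounds with values here, the one measured step that bears on this kind of change is the one from compound 2 to compound 3, where the same thiophene group was exchanged for 4-methylphenyl and the result was a number 3.3 percentage points higher from compound 2 to compound 3 (within the scatter), a change within the scatter. The step of a number 36.3 percentage points lower from compound 1 to compound 3 (beyond the scatter) concerns a substituent on the aryl group rather than the aryl group itself and says less about this case. A step no larger than the scatter, a number 4.8 percentage points higher from compound 2 to compound 4 (within the scatter), is therefore expected in this assay for compound 4. The estimate for compound 4 is 40%, with a range from 25% to 58%.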

Compound 4, a percentage reported as activity, at one concentration (the size of the read-out at that concentration, not a potency): 37.1%
The estimate for compound 4 lay 2.9 percentage points above the measured number; low and high end bracket the measured number.
By their numbers in this assay, from the lowest: compounds 2, 4 and 3 (each within the scatter of the next); then compound 1.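

Exchanging 5-chloro-2-sulfamoylthiophen-3-yl for 3-carbamoyl-4-hydroxyphenyl on the carbon with a double bond to nitrogen gives, in this assay, a number 1.9 percentage points higher from compound 2 to compound 4 (within the scatter), and exchanging 4-methylphenyl for the same group gives a number 1.4 percentage points lower from compound 3 to compound 4 (within the scatter). Three different aryl groups at this place therefore give numbers that cannot be told apart; carrying phenyl in place of the methyl of compound 3, compound 1 goes against this pattern with 74.8%. Nothing measured here explains this sameness.

The compounds shown leave open whether a butyl chain or a carboxylic acid in place of that phenyl would also give a number as high as that of compound 1. Going by these compounds, each number also comes from a single concentration, so how potent these compounds are remains open.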